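A 2-Methoxyphenyl in Place of a 4-Fluorophenyl

The source may report more compounds than this note shows. Statements on the series, on what has been measured and on what is new or still open speak of the compounds shown alone.

Compound 1 `CC1(C)CCN(c2ccc(C(=O)NS(=O)(=O)c3ccc(NC(C)(C)CSc4ccccc4)c([N+](=O)[O-])c3)cc2)CC1` gives 67 nM in an assay on isolated protein for displacement of a labelled ligand from Apoptosis regulator Bcl-2 (Homo sapiens), read by fluorescence polarization; a lower number here means a stronger inhibitor, a higher number a weaker inhibitor.
Compound 2 `CN(C)CC[C@H](CSc1ccccc1)Nc1ccc(S(=O)(=O)NC(=O)c2ccc(N3CCC(=Cc4ccc(F)cc4)CC3)cc2)cc1[N+](=O)[O-]` gives 3.4 nM in this assay.

Compound 2 holds the lowest number of the two, and compound 1 sits a wide gap above it. Compound 3 `COc1ccccc1C=C1CCN(c2ccc(C(=O)NS(=O)(=O)c3ccc(N[C@H](CCN(C)C)CSc4ccccc4)c([N+](=O)[O-])c3)cc2)CC1` has not yet been measured. It differs from compound 2 in one place: 2-methoxyphenyl in place of 4-fluorophenyl on a double-bonded chain carbon bound to a double-bonded ring carbon. Among the measured compounds shown here, no measured pair shows this kind of change, so its effect is open. Compound 3 is expected to stay close to compound 2, with a step of a 1.5-fold higher number from compound 2 to compound 3 (0.17 log units; within the scatter) that is expected to lie within the usual scatter. The estimate for compound 3 is 5 nM, between 1.5 nM and 20 nM.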

Compound 3, inhibition constant: 2 nM
Compound 3: the middle estimate sits 2.5-fold (0.40 log units) above what was measured, and the stated range covers the measured number.
By their numbers in this assay, from the lowest: compounds 3 and 2 (each within the scatter of the next); then compound 1.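

This pair gives a reading at this position that compound 1 and compound 2 could not, and in this assay it shows a 1.7-fold lower number from compound 2 to compound 3 (0.23 log units; within the scatter). At this carbon, then, 2-methoxyphenyl in place of 4-fluorophenyl, with one more hydrogen-bond acceptor and the fluorine gone, leaves the number within the scatter. Nothing measured here explains why the two groups read alike. Still open, on these data alone, is whether a plain phenyl, a pyridine or a cyclohexyl group at this carbon would read the same. A carboxylic acid or an amine on the ring is equally untested in the compounds shown.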